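The source may hold more compounds than are shown below. What is called first, only, known or untested is meant among the compounds shown, and "the series" means these compounds.

Values in a functional assay on PC-3 cells (Homo sapiens) for inhibition, read by MTT assay, with a stated time of 48 h; on this read-out lower numbers stand for stronger inhibition and higher numbers for weaker inhibition:
- compound 1 `COc1cc(-c2nnc(SC)n2-c2ccc(N(C)C)cc2)cc(OC)c1OC`: > 60000 nM (a limit of the assay)
- compound 2 `COc1cc(-c2nnc(SCc3ccccc3)n2-c2ccc(N(C)C)cc2)cc(OC)c1OC`: 55800 nM
- compound 3 `COc1cc(-c2nnc(SCC(=O)c3ccc4ccccc4c3)n2-c2ccc(N(C)C)cc2)cc(OC)c1OC`: 18100 nM

Among the measured compounds shown here, compound 3 has the lower of the two actual numbers, and the only other value is the limit for compound 1. The next compound is compound 4 `COc1cc(-c2nnc(SCC(=O)C3CC3)n2-c2ccc(N(C)C)cc2)cc(OC)c1OC`, with cyclopropyl in place of naphthalen-2-yl on a carbonyl carbon.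

For the measured compounds named here, three measured steps bear on this change. Placing (naphthalen-2-yl)carbonyl on the saturated chain carbon bound to a sulfur gave a 3.1-fold lower number from compound 2 to compound 3 (0.49 log units; beyond the scatter), and also an at least 3.3-fold lower number from compound 1 to compound 3 (0.52 log units; beyond the scatter). Phenyl at that carbon gave an at least 1.0-fold lower number from compound 1 to compound 2 (0.03 log units; that floor lies within the scatter). Going by the values given here, no measured compound carries cyclopropylcarbonyl, so the contribution of the naphthalen-2-yl alone is unknown.

A return towards weaker inhibition is expected in this assay, on the basis of a 3.1-fold lower number from compound 2 to compound 3 (0.49 log units; beyond the scatter). The expected change is a 2.1-fold higher number from compound 3 to compound 4 (0.32 log units; beyond the scatter). For compound 4 the estimate is 38000 nM, with an expected range of 16000 nM to 60000 nM.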

Compound 4, half-maximal inhibitory concentration: 45900 nM
Compound 4: the middle estimate sits 1.2-fold (0.08 log units) below what was measured, within the range that was stated.
By their numbers in this assay, from the lowest: compound 3; then compounds 4 and 2 (each within the scatter of the next). At a limit, above all of these: compound 1.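

In this assay, the naphthalen-2-yl group matters in its own right: with the carbonyl kept, cyclopropyl on the carbonyl carbon gives a 2.5-fold higher number from compound 3 to compound 4 (0.40 log units; beyond the scatter). The carbonyl on the saturated chain carbon bound to a sulfur is thus not enough by itself, since cyclopropylcarbonyl in place of phenyl gives a 1.2-fold lower number from compound 2 to compound 4 (0.08 log units; within the scatter), which leaves the two compounds indistinguishable. A step of an at least 1.3-fold lower number from compound 1 to compound 4 (0.11 log units; that floor lies within the scatter) is only a floor, set by a limit of the assay: the limit of > 60000 nM in this assay, at which 1 of the 4 values shown sits.

Open, as far as these compounds go, is whether both rings of the naphthalen-2-yl are needed, which phenyl on the carbonyl carbon would address. Also open, from the compounds shown here alone, is whether naphthalen-2-yl keeps its value on the chain carbon without the carbonyl, and how an amine or a carboxylic acid at that place would read.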